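The source may hold more compounds than are shown below. What is called first, only, known or untested is meant among the compounds shown, and "the series" means these compounds.

In an assay for inhibition of protein deacetylase HDAC6 (Homo sapiens) (on this read-out higher numbers stand for weaker inhibition and lower numbers for stronger inhibition), compound 1 `COc1ccc(-c2csc(NC(=O)[C@H](CCCCNS(N)(=O)=O)NC(=O)OCc3ccccc3)n2)cc1` gives 200 nM, while compound 2 `N[C@@H](CCCCNS(N)(=O)=O)C(=O)Nc1nc(-c2ccccc2)cs1` gives 1100 nM, the higher of the two numbers shown. Compound 3 `NS(=O)(=O)NCCCC[C@H](NC(=O)NCc1ccc(F)cc1)C(=O)Nc1nc(-c2ccccc2)cs1` differs from compound 2 by (4-fluorobenzyl)carbamoyl in place of hydrogen on an amine nitrogen. Among the measured compounds shown here, no step between two measured compounds covers exactly this change. Compound 3 is expected to give a lower number than compound 2, since the carbamate-capped compound 1 shows 200 nM in this assay. The step from compound 2 to compound 3 is estimated at a 4.4-fold lower number from compound 2 to compound 3 (0.64 log units; beyond the scatter). For compound 3 the estimate is 250 nM, with a range from 80 nM to 800 nM.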

Compound 3, half-maximal inhibitory concentration: 370 nM
Estimate against measurement, compound 3: 1.5-fold (0.17 log units) below; the range from low to high includes it.
By their numbers in this assay, from the lowest: compounds 1 and 3 (each within the scatter of the next); then compound 2.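

In this assay, (4-fluorobenzyl)carbamoyl in place of hydrogen on the amine nitrogen gives a 3.0-fold lower number from compound 2 to compound 3 (0.47 log units; beyond the scatter), a modest step. Among the compounds shown here, this is the first single-place change at this nitrogen, and it shows that a substituent with an aromatic ring can stand there without loss of inhibition and with a small gain. Nothing available explains this gain.

The compounds shown leave open which part of the substituent carries the step. A plain benzyl, an acetyl group or a chloro atom in place of the fluorine could separate the carbamoyl link from the ring and its fluorine.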